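Swapping a benzylcarbamoyl for a phenyl on a piperidine nitrogen

This account rests on a few compounds, and the source may have more. Where it says the series, first, only, none or still open, it means among the compounds named here.

Compounds measured so far:
compound 1, `O=C(/C(=N/O)Nc1ccc(F)c(Br)c1)C1CCN(C(=O)NCc2ccccc2)CC1`, with 43 nM
compound 2, `O=C(NC[C@H]1CC[C@H](C(=O)/C(=N/O)Nc2ccc(F)c(Br)c2)CC1)c1ccccc1`, with 80 nM

Two compounds share the same oxime-bearing core and differ in the ring that carries the ketone and in what is attached to it. In an assay for inhibition of Indoleamine 2,3-dioxygenase 1 (Homo sapiens), with a stated time of 1 h (on this read-out higher numbers stand for weaker inhibition and lower numbers for stronger inhibition), compound 1 gives 43 nM, the lower of the two numbers. Compound 2 gives 80 nM in this assay, and the gap between the two values lies within the usual scatter, so neither can be called the more potent.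

Compound 3, `O=C(/C(=N/O)Nc1ccc(F)c(Br)c1)C1CCN(c2ccccc2)CC1`, has not yet been measured. It keeps the core of compound 1 and changes one point: phenyl in place of benzylcarbamoyl on an amine nitrogen in a ring. No step between two measured compounds maps onto this change, so the direction of its effect is not shown by the data. Without a measured precedent, a moderate loss is expected rather than a gain, an estimated 3.5-fold higher number from compound 1 to compound 3 (0.54 log units; beyond the scatter) in this assay, a step that may or may not exceed the scatter. Compound 3 is thus expected to give about 150 nM in this assay, with a plausible range from 40 nM to 600 nM.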

Compound 3, half-maximal inhibitory concentration: 149 nM
For compound 3 the middle estimate is 1.0-fold (0.00 log units) above the measured one; the range from low to high includes it.
By their numbers in this assay, from the lowest: compounds 1, 2 and 3 (each within the scatter of the next, the first and the last beyond it).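

In this assay, putting phenyl in place of benzylcarbamoyl on an amine nitrogen in a ring gives a 3.5-fold higher number from compound 1 to compound 3 (0.54 log units; beyond the scatter). This is the first single-place change among these compounds, and it shows that the group on this nitrogen affects the read-out: the loss is modest, and compound 3 still gives a value of 149 nM. The benzylcarbamoyl carries 1 hydrogen-bond donor and 1 hydrogen-bond acceptor and the phenyl carries neither, though both contain a six-membered aromatic ring of carbon only, but no measurement here shows why the number rises.

One change removed several features at once, so the step cannot say whether the carbonyl, the amide hydrogen or the longer reach of the benzylcarbamoyl accounts for the difference. Going by these compounds, a benzyl group on the same nitrogen would keep the carbon chain link without the carbonyl, and a phenylcarbamoyl group would keep the carbonyl and the amide hydrogen with a shorter reach, so where each would fall relative to compound 1 and compound 3 remains open.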